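From an amide chain to methoxy(methyl)amino

The source may report more compounds than this note shows. Statements on the series, on what has been measured and on what is new or still open speak of the compounds shown alone.

Compound 1 (`CC(C)=CCCC1=CC[C@H](C(=O)Nc2ccc(O)cc2)[C@@H](c2ccccc2)C1`): 66700 nM
Compound 2 (`COC(=O)CCNC(=O)[C@H]1CC=C(CCC=C(C)C)C[C@@H]1c1ccccc1`): 96800 nM

Going by the values given here, in a functional assay on MCF7 cells (Homo sapiens) for antiproliferative activity (a higher number here means a weaker inhibitor, a lower number a stronger inhibitor), compound 2 lies within the scatter of compound 1, its only measured neighbour. Compound 3 (`CON(C)C(=O)[C@H]1CC=C(CCC=C(C)C)C[C@@H]1c1ccccc1`) has methoxy(methyl)amino in place of (2-(methoxycarbonyl)ethyl)amino on a carbonyl carbon. Among the compounds with values here, one measured step bears on this: a 1.5-fold higher number from compound 1 to compound 2 (0.16 log units; within the scatter) stays within the scatter, with 2-(methoxycarbonyl)ethyl in place of 4-hydroxyphenyl on an amide-type nitrogen. Within the data shown here, that is a different swap, and no measured compound lacks the amide hydrogen, so it is a weak guide. The change expected in this assay is a 1.2-fold lower number from compound 2 to compound 3 (0.08 log units; within the scatter) and no larger than the scatter. Compound 3 is estimated at 80000 nM with an expected range from 35000 nM to 180000 nM as its span.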

Compound 3, half-maximal inhibitory concentration: 42100 nM
Beside the measured number, compound 3's estimate is 1.9-fold (0.28 log units) above it; the measured number falls inside the stated range.
By their numbers in this assay, from the lowest: compounds 3, 1 and 2 (each within the scatter of the next, the first and the last beyond it).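

In this assay, going by these compounds alone, methoxy(methyl)amino on the carbonyl carbon gives a 2.3-fold lower number from compound 2 to compound 3 (0.36 log units; beyond the scatter) and so provides the first step here beyond the scatter, though a modest one. Set against (4-hydroxyphenyl)amino, the same group gives a 1.6-fold lower number from compound 1 to compound 3 (0.20 log units; within the scatter) and stays within the scatter, so an amide without its hydrogen holds up as well as one with it in this test. Nothing measured accounts for either step.

Going by these compounds, whether dimethylamino, morpholine or a free carboxylic acid on the same carbonyl carbon would shift the number further remains open.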